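This account rests on a few compounds, and the source may have more. Where it says the series, first, only, none or still open, it means among the compounds named here.

Measured so far:
compound 1 `O=C(O)/C=C/c1ccncc1-c1ccc2cc[nH]c2c1` — 2.4 nM
compound 2 `NNC(=O)COc1ccncc1-c1ccc2ccccc2c1` — "not determined" (no result reported)

Among the measured compounds shown here, compound 1 carries the only number in the set: in an assay on a protein complex for inhibition of CDK8/Cyclin C (Homo sapiens), with a stated time of 1 h (a higher number here means a weaker inhibitor, a lower number a stronger inhibitor), compound 1 gives 2.4 nM. Compound 2 has no result reported there, so it gives nothing to compare against. Compound 3 `CNC(=O)/C=C/c1ccncc1-c1ccc2cc[nH]c2c1` remains to be measured; against compound 1 the difference is methylamino in place of hydroxy on a carbonyl carbon. For the measured compounds named here, no step between measured compounds exists in the set, so the size of this change rests on judgement alone. For compound 3 the expected step is a 3.3-fold higher number from compound 1 to compound 3 (0.52 log units; beyond the scatter), a moderate loss beyond the scatter. Compound 3 is estimated at 8 nM, in a range from 2 nM to 40 nM.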

Compound 3, half-maximal inhibitory concentration: 18.6 nM
Beside the measured number, compound 3's estimate is 2.3-fold (0.37 log units) below it; the range from low to high includes it.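

In this assay, among the compounds shown here, methylamino in place of hydroxy on a carbonyl carbon gives a 7.8-fold higher number from compound 1 to compound 3 (0.89 log units; beyond the scatter) and this is the first measured step. The position is therefore sensitive to this change, although the step is modest. Inhibition does not depend on keeping the carboxy group intact, since compound 3 still reads 18.6 nM without it.

On these data alone, whether a primary amide, a methyl ester or a longer chain on the carbonyl carbon would narrow or widen this loss remains open. Nothing available accounts for the size of the step.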